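Biphenyl anilines bearing a hydroxybenzyl amine: propoxy for ethylsulfanyl

The source may hold more compounds than are shown below. What is called first, only, known or untested is meant among the compounds shown, and "the series" means these compounds.

Measured compounds:
- compound 1 `CC(C)(C)c1ccc(-c2ccc(NCc3ccccc3O)cc2)cc1`: "not active" (no number reported)
- compound 2 `Oc1ccccc1CNc1ccc(-c2ccc(-c3ccccc3)cc2)cc1`: "not active" (no number reported)
- compound 3 `CCSc1ccc(-c2ccc(NCc3ccccc3O)cc2)cc1`: 1980 nM

In a functional assay on Jurkat cells (Homo sapiens) for activation, with a stated time of 24 h (a higher number here means that more compound is needed for the effect, a lower number that less compound is needed), compound 1 is reported as "not active" (no number reported), with no number attached. Compound 2 is likewise reported in this assay as "not active" (no number reported). Going by the values given here, compound 3 is the only member of the series with a number in this assay, giving 1980 nM; against the two entries without a number it therefore stands alone, and no ranking among the three can be drawn.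

Compound 4 `CCCOc1ccc(-c2ccc(NCc3ccccc3O)cc2)cc1` has not yet been measured in this assay. The change from compound 3 is propoxy in place of ethylsulfanyl on an aromatic carbon. Among the compounds with values here, no step between two measured compounds is available to calibrate this change. The expectation is a step of a 1.5-fold higher number from compound 3 to compound 4 (0.18 log units; within the scatter) from compound 3 to compound 4 that stays within the usual scatter, with no strong direction implied. The estimate for compound 4 in this assay is 3000 nM, with a range from 1000 nM to 10000 nM.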

Compound 4, half-maximal effective concentration: "not active" (no number reported)
Nothing numeric was reported for compound 4; there is nothing to compare the estimate with.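

Going by these compounds alone, compound 3 gives 1980 nM and compound 4 gives "not active" (no number reported) and no step between the two can be read. As far as these compounds go, whether in this assay any group other than ethylsulfanyl on this aromatic carbon gives a number stays open. No measured evidence bears on this result.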